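The source may report more compounds than this note shows. Statements on the series, on what has been measured and on what is new or still open speak of the compounds shown alone.

Working notes on the series.

Compound 3 `C=CCn1c(=O)/c(=C\c2cccc(C)c2)[nH]c(=O)/c1=C\c1ccccc1OC` gives 20400 nM in a functional assay on BGC-823 cells (Homo sapiens) for cytotoxicity, read by CCK-8 assay, with a stated time of 72 h (a higher number here means a weaker inhibitor, a lower number a stronger inhibitor), the highest number of the three measured here. Compound 1 `C=CCn1c(=O)/c(=C\c2cccc(Cl)c2)[nH]c(=O)/c1=C\c1ccccc1OC` gives 4600 nM and compound 2 `C=CCn1c(=O)/c(=C\c2cccc(F)c2)[nH]c(=O)/c1=C\c1ccccc1OC` gives 5600 nM; the two are within the scatter of each other, as a 1.2-fold higher number from compound 1 to compound 2 (0.09 log units; within the scatter) shows. From these to compound 3 the numbers rise: a 4.4-fold higher number from compound 1 to compound 3 (0.65 log units; beyond the scatter) and a 3.6-fold higher number from compound 2 to compound 3 (0.56 log units; beyond the scatter), both modest but beyond the scatter.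

Compound 4 `C=CCn1c(=O)/c(=C\c2ccccc2F)[nH]c(=O)/c1=C\c1ccccc1OC` differs from compound 3 by 2-fluorophenyl in place of 3-methylphenyl on a double-bonded chain carbon bound to an aromatic carbon. The measured steps bear on it only in part. The swap of methyl for fluoro on the ring is covered by a 3.6-fold higher number from compound 2 to compound 3 (0.56 log units; beyond the scatter), which run backwards points to a lower number for compound 4 of a similar modest size. Where the fluorine sits on the ring changes as well, and no measured pair speaks to that, so the expectation rests on the methyl-to-fluoro exchange alone and carries a wider range.

For compound 4 the expected step is a 3.4-fold lower number from compound 3 to compound 4 (0.53 log units; beyond the scatter), a lower number beyond the scatter. Compound 4 is therefore estimated at 6000 nM, with a range of 2500 nM to 15000 nM.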

Compound 4, half-maximal inhibitory concentration: 18900 nM
Compound 4: the middle estimate sits 3.2-fold (0.50 log units) below what was measured; the measured number lies above the stated range.
By their numbers in this assay, from the lowest: compounds 1 and 2 (each within the scatter of the next); then compounds 4 and 3 (each within the scatter of the next).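

In this assay, moving the fluorine on the ring at the double-bonded chain carbon costs activity, with a 3.4-fold higher number from compound 2 to compound 4 (0.53 log units; beyond the scatter) and with a 4.1-fold higher number from compound 1 to compound 4 (0.61 log units; beyond the scatter), while a 1.1-fold lower number from compound 3 to compound 4 (0.03 log units; within the scatter) places 2-fluorophenyl level with 3-methylphenyl. The earlier compounds shown here carried only 3-chlorophenyl, 3-fluorophenyl and 3-methylphenyl, so they could show only a change of group; the comparison of 2-fluorophenyl with 3-fluorophenyl now shows that, with the same atoms, the location of the fluorine alone separates the numbers at this position. Nothing at hand accounts for this difference.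

Going by these compounds, whether chloro or methyl would respond to the same move on the ring as fluoro remains open. So does the response of this position to a ring bearing an amine, a carboxylic acid or a nitrile.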